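Stretching the acyl group on a shared diazabicyclic core

The source may report more compounds than this note shows. Statements on the series, on what has been measured and on what is new or still open speak of the compounds shown alone.

Three amides of one core have been measured in an assay on SH-EP1 cells for agonist activity at Neuronal acetylcholine receptor; alpha4/beta2 (Homo sapiens), read by FLIPR and calcium flux; on this read-out lower numbers stand for smaller maximal responses and higher numbers for larger maximal responses. Compound 1 `CC(=O)N1CC2CC(C1)N2` gives 94%, compound 2 `O=C(C1CCC1)N1CC2CC(C1)N2` gives 100%, and compound 3 `O=C(C1CCCC1)N1CC2CC(C1)N2` gives 48%. Compound 1 thus stands second highest of the three, close to compound 2 and far above compound 3. Going by the values given here, the one single-site step known, a number 6 percentage points higher from compound 1 to compound 2 (within the scatter), shows that a cyclobutyl on the carbonyl carbon changes little. Compound 4 `O=C(CC1C=CCC1)N1CC2CC(C1)N2` differs from compound 1 by cyclopent-2-en-1-yl in place of hydrogen on a saturated chain carbon bound to a carbonyl carbon. Among the compounds with values here, no measured step matches this change, but compound 3 shows that a larger group near the carbonyl can lower the response. The expected step is a number 34 percentage points lower from compound 1 to compound 4 (beyond the scatter), so compound 4 is estimated at 60%, between 35% and 90%.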

Compound 4, largest response reached (Emax), in percent of the reference or control that the assay uses: 89%
Beside the measured number, compound 4's estimate is 29 percentage points below it, within the range that was stated.
By their numbers in this assay, from the lowest: compound 3; then compounds 4, 1 and 2 (each within the scatter of the next, the first and the last beyond it).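

The step of a number 5 percentage points lower from compound 1 to compound 4 (within the scatter) in this assay shows that a saturated chain carbon bound to a carbonyl carbon can carry cyclopent-2-en-1-yl in place of hydrogen and keep the response of compound 1. The earlier compounds shown here could not show this, since their changes sit on the carbonyl carbon itself. Still open, going by these compounds, is whether an amine, a carboxylic acid or a longer chain on this same carbon would leave the response equally in place. Nothing available here explains why this ring leaves the response in place.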